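Swapping phenylsulfonyl for phenyl on a furoxan-bearing ascorbate

The source may hold more compounds than are shown below. What is called first, only, known or untested is meant among the compounds shown, and "the series" means these compounds.

Measured so far:
Compound 1, `O=C1OC(C(O)CO)C(O)=C1OCCCOc1no[n+]([O-])c1-c1ccccc1`: 32000 nM
Compound 2, `O=C1OC(C(O)CO)C(OCCCCCCO[N+](=O)[O-])=C1O`: 2100 nM
Compound 3, `O=C1OC(C(O)CO)C(OCCCOc2no[n+]([O-])c2S(=O)(=O)c2ccccc2)=C1O`: 34 nM

All three were tested in a functional assay on thoracic aorta (strain Wistar) for inhibition, with Aorta (Rattus norvegicus) as the target; a higher number here means that more compound is needed for the effect, a lower number that less compound is needed. Compound 3 gives the lowest number of the three, and its gap to compound 2 and to compound 1 lies beyond the scatter of repeat measurements, so compound 3 is the most potent of the measured set.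

The next compound, compound 4, `O=C1OC(C(O)CO)C(OCCCOc2no[n+]([O-])c2-c2ccccc2)=C1O`, differs from compound 3 in one place: phenyl in place of phenylsulfonyl on an aromatic carbon

For the measured compounds named here, no measured pair in this set differs in exactly one place, so there is no measured step to lean on. Compound 1, whose ring also bears phenyl rather than phenylsulfonyl, gives 32000 nM in this assay, though it differs from compound 4 in other ways as well. On that basis, compound 4 is expected to need clearly more compound than compound 3, a step of an 88-fold higher number from compound 3 to compound 4 (1.95 log units; beyond the scatter) that is expected to exceed the scatter. The estimate for compound 4 in this assay is 3000 nM, with a range from 500 nM to 20000 nM.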

Compound 4, half-maximal effective concentration in the Aorta assay: 3800 nM
Estimate against measurement, compound 4: 1.3-fold (0.10 log units) below, and the stated range covers the measured number.
By their numbers in the Aorta assay, from the lowest: compound 3; then compounds 2 and 4 (each within the scatter of the next); then compound 1.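

For the compounds shown here, this is the first pair here that differs in one place only, so the group on this aromatic carbon of the five-membered ring can be judged directly: in the Aorta assay, phenyl in place of phenylsulfonyl gives a 110-fold higher number from compound 3 to compound 4 (2.05 log units; beyond the scatter). Both groups hold the same six-membered aromatic ring of carbon only, so the pair shows that this ring alone does not set the number, and the large step goes with the sulfur and oxygen atoms that leave with phenylsulfonyl. In a physicochemical assay for lipophilicity, using the shake flask method, with a stated time of 4 h, at pH 1.0 (a higher number here means a more lipophilic compound, a lower number a more polar compound), compound 3 gives 1.18 and compound 4 gives 1.53, so the two also differ there, but this single pair cannot tell whether that difference has anything to do with the step in the Aorta assay.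

Two groups at one position cannot show whether the sulfonyl unit itself matters or whether another group holding oxygen or nitrogen would serve as well, and a methylsulfonyl group or a nitrile on this carbon would test that. From the compounds shown here alone, how a longer chain linking the shared core to the five-membered ring would change either compound also remains open.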